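Swapping the aryl chloro for dimethylamino in compound 1

The source may report more compounds than this note shows. Statements on the series, on what has been measured and on what is new or still open speak of the compounds shown alone.

Measured so far:
compound 1, `O=C1C2=C(C(=O)c3ncccc31)C1(CS2)NC(=O)N(c2ccc(Cl)cc2)C1=O`: 2 nM
compound 2, `O=C1NN(c2ccc(Cl)cc2)C(=O)C2(CSC3=C2C(=O)c2ncccc2C3=O)N1`: 220 nM

Compound 1 carries the lowest number of the two values in a functional assay on HT-29 cells (Homo sapiens) for antiproliferative activity, read by MTT assay, with a stated time of 96 h; a higher number here means a weaker inhibitor, a lower number a stronger inhibitor; in this assay compound 1 gives 2 nM. Compound 2, which has a different core, gives 220 nM in this assay, and the gap between these two values lies far beyond the scatter. Within the data shown here, no step between single-change pairs is available, so nothing about swapping groups on the aryl ring has yet been measured.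

Compound 3, `CN(C)c1ccc(N2C(=O)NC3(CSC4=C3C(=O)c3ncccc3C4=O)C2=O)cc1`, keeps the whole core of compound 1 and changes only the aryl substituent: dimethylamino in place of chloro on an aromatic carbon. Among the measured compounds shown here, since no measured pair shows what this change does, the expectation rests on compound 1 alone, whose value of 2 nM leaves more room for a weaker than for a stronger result. The step from compound 1 to compound 3 is expected to be small and towards a higher number, roughly a 3.0-fold higher number from compound 1 to compound 3 (0.48 log units; beyond the scatter), possibly within the scatter. For compound 3 the estimated value in this assay is 6 nM, with a range from 1.5 nM to 30 nM.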

Compound 3, half-maximal inhibitory concentration: 20 nM
For compound 3 the middle estimate is 3.3-fold (0.52 log units) below the measured one; low and high end bracket the measured number.
By their numbers in this assay, from the lowest: compound 1; then compound 3; then compound 2.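

In this assay, among these compounds, replacing chloro with dimethylamino gives the first single-change step, a 10-fold higher number from compound 1 to compound 3 (1.00 log units; beyond the scatter), and it shows that the result at this place on the six-membered aromatic ring depends on the group that sits there. The step lies beyond the scatter, yet compound 3 still gives 20 nM, so with the core of compound 1 unchanged, a group of more heavy atoms that adds a hydrogen-bond acceptor still leaves a value in the low nanomolar range. No measurement at hand explains this step.

A single exchange cannot separate what is lost with the chloro from what is gained with the dimethylamino, and compounds carrying a hydrogen, a fluoro, a methoxy or a primary amine at the same place would begin to tell these apart. Going by these compounds, it also remains open whether the same exchange would have a step of similar size on the core of compound 2, or whether a longer chain on the nitrogen of the amine would carry the trend further.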